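A few compounds are considered here, and "the series" means these few. Any claim that something is new, unique, unknown or untested is made for them only; others in the source may bear on it.

Measured compounds in a functional assay on cells (Panel CNS (Carcinoma cell lines), Homo sapiens) for inhibition; a lower number here means a stronger inhibitor of growth, a higher number a weaker inhibitor of growth:

compound 1, `Oc1cc(-c2cccc(Cl)c2)nc2ncccc12`: 16600 nM
compound 2, `Cc1cc(C)c2c(O)cc(-c3cccc(Cl)c3)nc2n1`: 5010 nM

Of the two numbers in this assay, compound 2 stands at the lower one, and the gap to compound 1 lies beyond the usual scatter, so compound 2 is the stronger inhibitor of growth of the pair. No other comparison among measured compounds is available, and the two share the same chloro-bearing ring.

Compound 3, `Cc1cc(C)c2c(O)cc(-c3cccc(F)c3)nc2n1`, is not yet measured. Relative to compound 2 it differs in one place: fluoro in place of chloro on an aromatic carbon. Nothing measured in the set speaks to this exchange. The expectation is a small step from compound 2 to compound 3 toward a higher number, of a size that may well remain within the scatter; the expected step is a 1.6-fold higher number from compound 2 to compound 3 (0.20 log units; within the scatter). For compound 3 the estimate in this assay is 8000 nM, within a range from 3000 nM to 25000 nM.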

Compound 3, concentration for total growth inhibition: 9770 nM
Compound 3: the middle estimate sits 1.2-fold (0.09 log units) below what was measured, within the range that was stated.
By their numbers in this assay, from the lowest: compounds 2, 3 and 1 (each within the scatter of the next, the first and the last beyond it).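

In this assay, fluoro in place of chloro on an aromatic carbon gives a 2.0-fold higher number from compound 2 to compound 3 (0.29 log units; within the scatter) and so stays within the scatter. Among these compounds, this is the first reading of any change at this place, meta to a large group on the six-membered aromatic ring of carbon only, and the two halogens cannot be told apart there. No measurement at hand bears on this step.

Open, on these data alone, is whether a larger exchange at the same place, such as a methoxy group or an amine, would give a step beyond the scatter. Also open, as far as these compounds go, is what happens when the hydroxyl on the shared core gives way to an amine or a methoxy group, with either halogen kept in place.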